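Swapping fluoro for chloro on a benzyl group

The compounds below may be only part of what the source reports. "The series", "measured", "known", "first", "only" and "open" are said of these compounds alone.

In an ADME assay on the whole organism (Rattus norvegicus, strain Sprague-Dawley) for pharmacokinetics, using cassette dosing, at a dose of 0.5 mg/kg by the intravenous route (a higher number here means faster removal of the compound, a lower number slower removal), compound 3 (`O=C(c1cc(-c2ccc(=O)[nH]c2)on1)N1CCC(Cc2ccc(F)cc2)CC1`) gives 19.7 mL/min/kg in rats. Compound 2 (`O=C(c1cc(-c2ccc(=O)[nH]c2)on1)N1CCC(Cc2ccccc2)CC1`) gives 19.3 mL/min/kg and compound 1 (`O=C(c1cc(-c2cn[nH]c2)on1)N1CCC(Cc2ccc(Cl)cc2)CC1`) gives 29.2 mL/min/kg in the same test, so compound 3 sits within the usual scatter of both.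

Compound 4 (`O=C(c1cc(-c2ccc(=O)[nH]c2)on1)N1CCC(Cc2ccc(Cl)cc2)CC1`) differs from compound 3 by one swap, chloro in place of fluoro on an aromatic carbon, para to a large group: chloro in place of fluoro on an aromatic carbon and so 4-fluorobenzyl becomes 4-chlorobenzyl.

The nearest measured step, fluoro in place of hydrogen on an aromatic carbon, was a 1.0-fold higher number from compound 2 to compound 3 (0.01 log units; within the scatter) and on that basis no step beyond the scatter is expected in this assay for the new swap. Among the measured compounds shown here, no measured step isolates chloro itself. Compound 1 does carry a 4-chlorobenzyl group, and its 29.2 mL/min/kg lies within the scatter of compound 3, which fits that expectation.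

The expected step is a 1.1-fold higher number from compound 3 to compound 4 (0.03 log units; within the scatter) and this estimate stays within the scatter. For compound 4 the estimated clearance is 21 mL/min/kg with an expected range from 13 mL/min/kg to 33 mL/min/kg in this measurement.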

Compound 4, clearance: 5.4 mL/min/kg
Compound 4: the middle estimate sits 3.9-fold (0.59 log units) above what was measured; measured number below the stated range.
By their numbers in this assay, from the lowest: compound 4; then compounds 2, 3 and 1 (each within the scatter of the next).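

In this assay the carbon para to a large group on the benzyl ring turns out to respond to the halogen placed there: chloro in place of fluoro gives a 3.6-fold lower number from compound 3 to compound 4 (0.56 log units; beyond the scatter) on this measure, and chloro in place of hydrogen gives a 3.6-fold lower number from compound 2 to compound 4 (0.55 log units; beyond the scatter) on the same measure. Fluoro in place of hydrogen had given a 1.0-fold higher number from compound 2 to compound 3 (0.01 log units; within the scatter) here, so the earlier pair showed no response at this carbon, and the change from 4-fluorobenzyl to 4-chlorobenzyl shows that the choice of halogen matters. With 4-chlorobenzyl held fixed, the group at the other end matters as well: the group of 7 heavy atoms of compound 4 in place of the group of 5 heavy atoms of compound 1 gives a 5.4-fold lower number from compound 1 to compound 4 (0.73 log units; beyond the scatter) in this test, so chloro alone does not set the clearance.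

As far as these compounds go, whether bromo, methyl or trifluoromethyl at the same carbon would give a number like that of compound 4 remains open, as does whether other groups at the far end of the core would keep it there. Nothing shown here explains why the clearance of compound 4 differs from that of its neighbours.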